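Ester to Methyl Amide on a Triazolopyridine Sulfonamide

This account rests on a few compounds, and the source may have more. Where it says the series, first, only, none or still open, it means among the compounds named here.

Measured compounds:
Compound 1, `COc1ncc(-c2ccc3nc(N)nn3c2)cc1NS(=O)(=O)c1ccc(F)cc1`, 3950 nM
Compound 2, `CCOC(=O)CNc1nc2ccc(-c3cnc(OC)c(NS(=O)(=O)c4ccc(F)cc4)c3)cn2n1`, 7940 nM

In a functional assay on U-87MG ATCC cells (Homo sapiens) for antiproliferative activity, read by MTT assay, with a stated time of 48 h (on this read-out lower numbers stand for stronger inhibition and higher numbers for weaker inhibition), compound 1 gives 3950 nM, and compound 2 gives 7940 nM. Going by the values given here, the one measured step, a 2.0-fold higher number from compound 1 to compound 2 (0.30 log units; within the scatter), places compound 2 within the scatter of compound 1, so the two numbers cannot be ordered with confidence; compound 2 simply carries the (ethoxycarbonyl)methyl group on the ring nitrogen that compound 1 lacks.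

Compound 3, `CNC(=O)CNc1nc2ccc(-c3cnc(OC)c(NS(=O)(=O)c4ccc(F)cc4)c3)cn2n1`, is not yet measured. It differs from compound 2 by methylamino in place of ethoxy on a carbonyl carbon; cut one bond further out, the change reads ethoxycarbonyl to methylcarbamoyl. Among the compounds with values here, no measured step touches this carbonyl substituent, so only the indirect evidence remains: attaching the whole ester side chain gave a 2.0-fold higher number from compound 1 to compound 2 (0.30 log units; within the scatter), a step that stayed within the scatter. A change confined to the far end of that chain is therefore expected to move this assay little, if at all, and no direction beyond the scatter is predicted. Compound 3 is estimated at 6300 nM, within the range 2000 nM to 20000 nM, an expected step of a 1.3-fold lower number from compound 2 to compound 3 (0.10 log units; within the scatter).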

Compound 3, half-maximal inhibitory concentration: 7290 nM
The estimate for compound 3 lay 1.2-fold (0.06 log units) below the measured number, within the range that was stated.
By their numbers in this assay, from the lowest: compounds 1, 3 and 2 (each within the scatter of the next).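

In this assay, methylamino in place of ethoxy on the carbonyl carbon gives a 1.1-fold lower number from compound 2 to compound 3 (0.04 log units; within the scatter), so at the far end of this side chain the ester and the methyl amide cannot be told apart, even though methylamino brings a hydrogen-bond donor that ethoxy lacks. Measured against compound 1, which has hydrogen on the nitrogen, the amide side chain gives a 1.8-fold higher number from compound 1 to compound 3 (0.27 log units; within the scatter), and the ester side chain gives a 2.0-fold higher number from compound 1 to compound 2 (0.30 log units; within the scatter), so neither side chain separates from hydrogen at this position. No supporting data are available to explain why this exchange leaves the reading within the scatter.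

Going by these compounds, all three compounds lie within the scatter of one another, so it remains open whether any group on this nitrogen can shift the number at all. Nor do these compounds show whether a carboxylic acid or a dimethylamide at the carbonyl, or a longer chain between the nitrogen and the carbonyl, would read differently in this assay.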